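This account rests on a few compounds, and the source may have more. Where it says the series, first, only, none or still open, it means among the compounds named here.

Compounds measured in a functional assay on CHO cells for agonist activity at Free fatty acid receptor 2 (Homo sapiens), read by cAMP accumulation; a higher number here means a weaker inhibitor, a lower number a stronger inhibitor:
compound 1 `CC(C)[C@H](C(=O)Nc1ccccn1)c1ccc(Cl)cc1` gives 1400 nM;
compound 2 `CC(C)[C@H](C(=O)Nc1nncs1)c1ccc(Cl)cc1` gives 12000 nM;
compound 3 `CC(C)[C@H](C(=O)Nc1nnc(C(F)(F)F)s1)c1ccc(Cl)cc1` gives 1900 nM.

Compound 2 stands with the highest number of the three. Compound 4 `Cc1csc(NC(=O)[C@H](c2ccc(Cl)cc2)C(C)C)n1` differs from it in one place: 4-methyl-1,3-thiazol-2-yl in place of 1,3,4-thiadiazol-2-yl on an amide-type nitrogen. Going by the values given here, two measured steps bear on this change. Replacing the ring on the amide-type nitrogen gave an 8.6-fold higher number from compound 1 to compound 2 (0.93 log units; beyond the scatter), and adding a group on that ring gave a 6.3-fold lower number from compound 2 to compound 3 (0.80 log units; beyond the scatter). Compound 4 carries a ring with fewer hetero atoms than compound 2 and also bears a substituent, so a step in this assay towards a lower number, of modest size, is expected, a 6.0-fold lower number from compound 2 to compound 4 (0.78 log units; beyond the scatter). Compound 4 is therefore estimated at 2000 nM, with a range from 600 nM to 6000 nM.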

Compound 4, half-maximal inhibitory concentration: 1400 nM
For compound 4 the middle estimate is 1.4-fold (0.15 log units) above the measured one; measured number inside the range.
By their numbers in this assay, from the lowest: compounds 1, 4 and 3 (each within the scatter of the next); then compound 2.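

The change to 4-methyl-1,3-thiazol-2-yl on the amide-type nitrogen gives an 8.6-fold lower number from compound 2 to compound 4 (0.93 log units; beyond the scatter) in this assay and no change at the digits printed from compound 1 to compound 4 (within the scatter) when it takes the place of pyridin-2-yl. Trifluoromethyl is therefore not the only route away from the high number of compound 2, since a different ring bearing methyl also leaves it behind. No measurement given here explains this step.
Whether the methyl or the ring itself accounts for the step stays open, as the compounds shown do not separate the two. Nor do they show how an unsubstituted 1,3-thiazol-2-yl or a ring bearing an amine would compare.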